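The source may report more compounds than this note shows. Statements on the series, on what has been measured and on what is new or still open speak of the compounds shown alone.

Compound 1 `Nc1ccn2nc(-c3ccc(F)cc3)c(-c3ccnc(NC4CCCC4)n3)c2c1` carries an amino group on the shared core, and in an ADME assay on Vero cells (Chlorocebus sabaeus) for cytotoxicity (a higher number here means that more compound is tolerated, a lower number that less compound is tolerated), compound 1 gives 20000 nM. Compound 2 `Fc1ccc(-c2nn3ccc(N4CCCC4)cc3c2-c2ccnc(NC3CCCC3)n2)cc1` differs from it in one place, pyrrolidin-1-yl in place of amino on an aromatic carbon. In this assay compound 2 reaches only a limit of the assay, > 40000 nM. The recorded step is an at least 2.0-fold higher number from compound 1 to compound 2 (0.30 log units; that floor lies within the scatter), and since its floor lies within the scatter the two values do not separate. On the numbers shown, compound 2 therefore stands at the limit of > 40000 nM in this assay, at which 1 of the 2 values shown sits.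

Compound 3 `COCCNc1ccn2nc(-c3ccc(F)cc3)c(-c3ccnc(NC4CCCC4)n3)c2c1` is the next member: (2-methoxyethyl)amino in place of pyrrolidin-1-yl on an aromatic carbon. Among the compounds with values here, the single measured step that bears on this change, an exchange of the substituent on the same aromatic carbon, was small, and the data do not fix the size of any effect of the (2-methoxyethyl)amino group. No step beyond the scatter is therefore expected in this assay, in either direction. Compound 3 is expected to give about 30000 nM, with a range from 12000 nM to 60000 nM. This estimate means an expected step of an at least 1.3-fold lower number from compound 2 to compound 3 (0.12 log units; that floor lies within the scatter).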

Compound 3, half-maximal cytotoxic concentration: > 40000 nM
Compound 3: a limit, no number (the forecaster's own chance of this, stated with the estimate: 35%); at least 1.3-fold (0.12 log units) between middle value and limit.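

In this assay compound 3 also ends at a limit and not at a number, so a second substituent on this aromatic carbon, the open (2-methoxyethyl)amino chain with 1 hydrogen-bond donor in place of the pyrrolidin-1-yl ring with 0, gives the same limit as compound 2: the limit of > 40000 nM in this assay, at which 2 of the 3 values shown sit.

Measured against the amino group of the first compound, the recorded step is an at least 2.0-fold higher number from compound 1 to compound 3 (0.30 log units; that floor lies within the scatter), and since its floor lies within the scatter, these two values do not separate any more than the earlier pair did. The step between compound 2 and compound 3 cannot be read, as both values are limits, so the exchange of ring for chain has no size in these data.

From the compounds shown here alone, what number compound 2 and compound 3 would give in this assay stays open, and so does whether either substituent truly differs from the amino group of compound 1. Going by these compounds, it is also open whether a carboxylic acid or a longer amine chain on this aromatic carbon would give a value that can be read as a number.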